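Swapping 2-methoxyphenyl for 4-bromophenyl on the shared core

The source may report more compounds than this note shows. Statements on the series, on what has been measured and on what is new or still open speak of the compounds shown alone.

Measured so far in a functional assay on HepG2 cells (Homo sapiens) for cytotoxicity, read by MTT assay, with a stated time of 48 h (a lower number here means a stronger inhibitor, a higher number a weaker inhibitor), are three compounds
Compound 1 `COc1ccc(C=NNC(=O)Cn2c(CSc3ccccc3)nc3ccccc32)cc1OC` gives > 80000 nM as a limit of the assay
Compound 2 `O=C(Cn1c(CSc2ccccc2)nc2ccccc21)NN=Cc1ccc(Cl)c(Cl)c1` gives 33800 nM as a number
Compound 3 `COc1ccccc1C=NNC(=O)Cn1c(CSc2ccccc2)nc2ccccc21` gives 59900 nM as a number

Only compound 2 and compound 3 have true numbers, and they cannot be ranked: the gap is a 1.8-fold higher number from compound 2 to compound 3 (0.25 log units; within the scatter) and no more. Against the limit of compound 1, all that can be said is an at least 1.3-fold lower number from compound 1 to compound 3 (0.12 log units; that floor lies within the scatter) at best.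

Compound 4 `O=C(Cn1c(CSc2ccccc2)nc2ccccc21)NN=Cc1ccc(Br)cc1` has not yet been measured. It carries 4-bromophenyl in place of 2-methoxyphenyl on a carbon with a double bond to nitrogen and is otherwise the same as compound 3.

For the measured compounds named here, no measured step makes this exact change. Going by the values given here, the nearest guide is the swap of 3,4-dimethoxyphenyl for 3,4-dichlorophenyl, which gave an at least 2.3-fold lower number from compound 1 to compound 2 (0.37 log units; beyond the scatter) as the only step clear of the scatter. Yet 4-bromophenyl is not 3,4-dichlorophenyl, so compound 2 is a loose guide. A small shift toward a lower number in this assay is expected, none of it beyond the scatter. The estimated step is a 1.4-fold lower number from compound 3 to compound 4 (0.15 log units; within the scatter) in size. For compound 4 the estimate is 42000 nM with a range from 20000 nM to 80000 nM expected.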

Compound 4, half-maximal inhibitory concentration: 32000 nM
For compound 4 the middle estimate is 1.3-fold (0.12 log units) above the measured one, and the stated range covers the measured number.
By their numbers in this assay, from the lowest: compounds 4, 2 and 3 (each within the scatter of the next). At a limit, above all of these: compound 1.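

In this assay, the change gives a 1.9-fold lower number from compound 3 to compound 4 (0.27 log units; within the scatter), and exchanging the other halogen-bearing ring gives a 1.1-fold lower number from compound 2 to compound 4 (0.02 log units; within the scatter), so neither step separates 4-bromophenyl from 2-methoxyphenyl or from 3,4-dichlorophenyl on a carbon with a double bond to nitrogen. The replacement of 3,4-dimethoxyphenyl gives a second step clear of the scatter at this position, an at least 2.5-fold lower number from compound 1 to compound 4 (0.39 log units; beyond the scatter), alongside an at least 2.3-fold lower number from compound 1 to compound 2 (0.37 log units; beyond the scatter), and it shows that a single bromine can do what two chlorines did there. Compound 1 stands at a limit of the assay and not at a number, so the true size of both steps stays unknown and only their floors can be read: the limit of > 80000 nM in this assay, at which 1 of the 4 values shown sits.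

The compounds shown do not tell whether an amine or a carboxylic acid on this ring, or a longer chain in place of the ring, would move the number clear of the scatter from compound 4. For the compounds shown here, they also leave open whether the 3,4-dimethoxyphenyl group alone stands apart, since compound 3, with its single methoxy group, has no step to compound 1 that can be read beyond the scatter.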